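A few compounds are considered here, and "the series" means these few. Any claim that something is new, unique, unknown or untested is made for them only; others in the source may bear on it.

Compound 2 `CC(=O)OCCSCC1CN(C)CCC1c1ccc(Cl)cc1` gives the lowest number of the three measured compounds in an assay on isolated protein for inhibition of sodium-dependent dopamine transporter (Rattus norvegicus), read by radioligand binding (on this read-out lower numbers stand for stronger inhibition and higher numbers for weaker inhibition), at 35 nM. Compound 3 `CN1CCC(c2ccc(Cl)cc2)C(CSCCOC(=O)c2ccccc2)C1` gives 68 nM in this assay, a difference that stays a 1.9-fold higher number from compound 2 to compound 3 (0.29 log units; within the scatter). Compound 1 `COC(=O)C[S+]([O-])CC1CN(C)CCC1c1ccc(Cl)cc1`, with its sulfoxide and methyl ester, gives 231 nM, and the step of a 6.6-fold lower number from compound 1 to compound 2 (0.82 log units; beyond the scatter) is the only one here that reaches beyond the scatter.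

Compound 4 `CNC(=O)C[S+]([O-])CC1CN(C)CCC1c1ccc(Cl)cc1` differs from compound 2 in that (a group of 7 heavy atoms (3 carbon, 1 nitrogen, 2 oxygen, 1 sulfur; no ring) in place of a group of 7 heavy atoms (4 carbon, 2 oxygen, 1 sulfur; no ring), on a saturated chain carbon bound to a saturated ring carbon). Among the compounds with values here, of the measured steps, the one from compound 1 to compound 2 bears most directly on this change, since compound 4 shares with compound 1 the sulfoxide and the carbonyl set one carbon from the sulfur. Reversing a change of that kind suggests a step back toward higher numbers. Compound 4 is therefore expected to show a 5.7-fold higher number from compound 2 to compound 4 (0.76 log units; beyond the scatter) in this assay. The estimate for compound 4 is 200 nM, with a range from 70 nM to 600 nM.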

Compound 4, inhibition constant: 164 nM
Beside the measured number, compound 4's estimate is 1.2-fold (0.09 log units) above it; the measured number falls inside the stated range.
By their numbers in this assay, from the lowest: compounds 2 and 3 (each within the scatter of the next); then compounds 4 and 1 (each within the scatter of the next).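

In this assay, the change on the saturated chain carbon bound to a saturated ring carbon gives a 4.7-fold higher number from compound 2 to compound 4 (0.67 log units; beyond the scatter), so an amide-bearing sulfoxide chain also separates from the (2-acetoxyethyl)sulfanyl group beyond the scatter. The carbonyl substituent itself does not register here: methylamino in place of methoxy gives a 1.4-fold lower number from compound 1 to compound 4 (0.15 log units; within the scatter), which stays within the scatter. Compound 1 and compound 4 therefore cannot be told apart, whether the carbonyl carries methoxy or methylamino. Nothing available explains these steps.

Since the step to compound 4 alters the sulfur and the rest of the chain at once, the compounds shown do not say which part accounts for it. A thioether carrying the same methylamino carbonyl chain, or a sulfone or carboxylic acid at this place, would help separate these contributions.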